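Aryl swap on the isoxazole: from compound 2 to compound 3

A few compounds are considered here, and "the series" means these few. Any claim that something is new, unique, unknown or untested is made for them only; others in the source may bear on it.

Among the compounds with values here, compound 2 `N#Cc1cccc(-c2cc(COC(Cc3cn(C4CCN(Cc5ccc([N+](=O)[O-])cc5)CC4)nn3)c3ccc(Br)cc3)on2)c1` gives the only number in a functional assay on MCF7 cells (Homo sapiens) for cytotoxicity, with a stated time of 48 h (a lower number here means a stronger inhibitor, a higher number a weaker inhibitor), 2000 nM. Compound 1 `O=[N+]([O-])c1ccc(CN2CCC(n3cc(CC(OCc4cc(-c5ccccc5)no4)c4ccc(Br)cc4)nn3)CC2)cc1` gives in this assay only a limit, > 25000 nM (the limit of > 25000 nM in this assay, at which 1 of the 2 values shown sits). Within the data shown here, the single measured step, an at least 12-fold lower number from compound 1 to compound 2 (1.09 log units; beyond the scatter), bears on compound 3 `O=[N+]([O-])c1ccc(CN2CCC(n3cc(CC(OCc4cc(-c5ccccc5Br)no4)c4ccc(Br)cc4)nn3)CC2)cc1`, where (2-bromophenyl in place of 3-cyanophenyl on an aromatic carbon). Among the measured compounds shown here, the cyano introduced in that step is absent from compound 3, and no measured step shows what a bromine does here. The expected step is a 6.0-fold higher number from compound 2 to compound 3 (0.78 log units; beyond the scatter), a weakening beyond the scatter. For compound 3 the estimate in this assay is 12000 nM, with a range of 3000 nM to 50000 nM.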

Compound 3, half-maximal inhibitory concentration: 6000 nM
Estimate against measurement, compound 3: 2.0-fold (0.30 log units) above; measured number inside the range.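

In this assay, the gain at this position on the five-membered aromatic ring is no longer tied to the nitrile: 2-bromophenyl also beats plain phenyl, an at least 4.1-fold lower number from compound 1 to compound 3 (0.61 log units; beyond the scatter). It still falls short of 3-cyanophenyl, a 3.0-fold higher number from compound 2 to compound 3 (0.48 log units; beyond the scatter). Compound 1 stands only at a limit, so the step from it has no fixed size: the limit of > 25000 nM in this assay, at which 1 of the 3 values shown sits.

From the compounds shown here alone, compound 2 and compound 3 differ in both the substituent and its place on the phenyl ring, so which of the two carries the difference stays open. Also open, going by these compounds, is how an amine or a carboxylic acid on that phenyl would read.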